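Swapping One Halogenated Phenyl Group for Another

A few compounds are considered here, and "the series" means these few. Any claim that something is new, unique, unknown or untested is made for them only; others in the source may bear on it.

In a functional assay on HepG2 cells (Homo sapiens) for antiproliferative activity, read by MTT assay, with a stated time of 48 h (on this read-out higher numbers stand for weaker inhibition and lower numbers for stronger inhibition), compound 2 `O=C(/C=C/c1ccccc1)Nc1cc2c(Nc3cccc(Cl)c3F)ncnc2s1` gives 44600 nM. Within the data shown here, compound 1 `COc1ccc(/C=C/C(=O)Nc2cc3c(Nc4cc(Cl)cc(Cl)c4)ncnc3s2)cc1` gives 41800 nM, and these two numbers lie within the usual scatter of each other, so compound 2 stands level with the only other compound measured so far.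

Compound 3 `O=C(/C=C/c1ccccc1)Nc1cc2c(Nc3cc(Cl)cc(Cl)c3)ncnc2s1` differs from compound 2 in one place: 3,5-dichlorophenyl in place of 3-chloro-2-fluorophenyl on a nitrogen on an aromatic ring. In words, it has 3,5-dichlorophenyl in place of 3-chloro-2-fluorophenyl on a nitrogen on an aromatic ring.

Among the measured compounds shown here, no measured pair shows this exact swap, so there is no direct guide. However, compound 1 also carries the 3,5-dichlorophenyl group and gives 41800 nM, so no shift beyond the scatter is expected. The expected change is a 1.1-fold lower number from compound 2 to compound 3 (0.05 log units; within the scatter), which is small. The estimate in this assay for compound 3 is 40000 nM, with an expected range from 15000 nM to 100000 nM.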

Compound 3, half-maximal inhibitory concentration: 21800 nM
Compound 3: middle estimate off by 1.8-fold (0.26 log units), on the high side; the measured number falls inside the stated range.
By their numbers in this assay, from the lowest: compounds 3, 1 and 2 (each within the scatter of the next, the first and the last beyond it).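

Placing 3,5-dichlorophenyl in place of 3-chloro-2-fluorophenyl on the nitrogen gives a 2.0-fold lower number from compound 2 to compound 3 (0.31 log units; beyond the scatter) in this assay, so this position responds to a swap between these two halogenated phenyl groups, though only modestly. Hydrogen in place of methoxy on an aromatic carbon gives a 1.9-fold lower number from compound 1 to compound 3 (0.28 log units; within the scatter), which stays within the scatter, so the methoxy group on the other end of the molecule makes no clear difference between compound 1 and compound 3. Nothing available here accounts for the shift seen at the nitrogen.

On these data alone, the swap changes the fluorine and the chlorine pattern together, so the share of each remains open. Also open, as far as these compounds go, is how a plain phenyl, or a phenyl carrying an amine or a carboxylic acid, would read at this nitrogen.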